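The source may report more compounds than this note shows. Statements on the series, on what has been measured and on what is new or still open speak of the compounds shown alone.

Measured compounds in a functional assay on UO-31 cells (Homo sapiens) for inhibition, read by sulforhodamine B assay, with a stated time of 48 h; a higher number here means a weaker inhibitor of growth, a lower number a stronger inhibitor of growth:
compound 1 `Nc1cc(N)c2nc(-c3ccccc3)c(NCc3ccc(Cl)c(Cl)c3)nc2c1`, 4170 nM
compound 2 `Nc1cc(N)c2nc(-c3ccccc3)c(Sc3ccc(F)cc3)nc2c1`, a limit only, < 100000 nM
compound 3 `Nc1cc(N)c2nc(-c3ccccc3)c(Oc3ccc(F)cc3)nc2c1`, 13500 nM

Among the measured compounds shown here, of the two numbers known, compound 1 stands lowest; compound 3 sits at a higher number, and that gap lies beyond the scatter. For compound 2 only a limit is known, (the limit of < 100000 nM in this assay, at which 1 of the 3 values shown sits). For the measured compounds named here, the single step between measured compounds, a step that the limit leaves unreadable from compound 2 to compound 3, stays unreadable because of the limit of < 100000 nM in this assay, at which 1 of the 3 values shown sits.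

Compound 4 `COc1ccc(CNc2nc3cc(N)cc(N)c3nc2-c2ccccc2)cc1` differs from compound 1 in the benzyl arm: 4-methoxyphenyl in place of 3,4-dichlorophenyl on a saturated chain carbon bound to a nitrogen on an aromatic ring. Going by the values given here, neither measured step touches this arm; the measured step concerns the other substituent on the shared core, so no measured step bears on the change from compound 1 to compound 4, and its size must rest on the change itself. The expected step is a 1.9-fold higher number from compound 1 to compound 4 (0.28 log units; within the scatter), with a wide band and no firm direction. For compound 4 the estimate in this assay is 8000 nM, expected to fall between 2000 nM and 40000 nM.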

Compound 4, concentration for 50% growth inhibition: 11500 nM
Compound 4: the middle estimate sits 1.4-fold (0.16 log units) below what was measured, and the stated range covers the measured number.
By their numbers in this assay, from the lowest: compound 1; then compounds 4 and 3 (each within the scatter of the next).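

In this assay, among the compounds shown here, the only readable step at the benzyl arm is a 2.8-fold higher number from compound 1 to compound 4 (0.44 log units; beyond the scatter), with 4-methoxyphenyl in place of 3,4-dichlorophenyl on a saturated chain carbon bound to a nitrogen on an aromatic ring. The arm therefore has a measured effect on the number, even though the two groups match in heavy-atom count and each holds one six-membered aromatic ring of carbon only; the entering group adds one hydrogen-bond acceptor. Nothing measured here accounts for the size or direction of this step.

As far as these compounds go, the swap alters the chlorine and methoxy substitution together, so the share of each in the step stays open. An unsubstituted benzyl, a 4-chlorobenzyl or a longer phenethyl chain on the same nitrogen would help separate these contributions.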